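Halogen swap on the aryl piperazine of the oxazole series

The compounds below may be only part of what the source reports. "The series", "measured", "known", "first", "only" and "open" are said of these compounds alone.

Compound 1 `CCCc1nc(-c2ccccc2)c(CNCCN2CCN(c3ccc(Cl)cc3)CC2)o1` gives 55.8% in an assay on HEK293 cells for inhibition of Voltage-dependent T-type calcium channel subunit alpha-1G (Homo sapiens), read by fluorescence, tested at 10 uM; on this read-out lower numbers stand for less inhibition and higher numbers for more inhibition at the one concentration tested (going by the name of the read-out).
Compound 2 `CCCc1nc(-c2ccccc2)c(CNCCN2CCN(c3cccc(OC)c3)CC2)o1` gives 40.2% in this assay.
Compound 3 `CCCc1nc(-c2ccccc2)c(CNCCN2CCN(c3cccc(F)c3)CC2)o1` gives 62.3% in this assay.

Compound 3 carries the highest of the three numbers. Its nearest neighbour is compound 1, with a number 6.5 percentage points higher from compound 1 to compound 3 (within the scatter), so the two cannot be ordered; only compound 2 lies clearly apart, with a number 22.1 percentage points higher from compound 2 to compound 3 (beyond the scatter). Among the measured compounds shown here, the one step that is beyond the scatter, a number 15.6 percentage points lower from compound 1 to compound 2 (beyond the scatter), also involves the methoxy compound.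

Compound 4 `CCCc1nc(-c2ccccc2)c(CNCCN2CCN(c3cccc(Cl)c3)CC2)o1` differs from compound 3 in one place: chloro in place of fluoro on an aromatic carbon. For the measured compounds named here, no measured pair changes one halogen for another at the same position. The closest information is compound 1, where a 4-chlorophenyl rather than the 3-fluorophenyl of compound 3 sits on the piperazine nitrogen and the number moves only within the scatter. Both halogen compounds sit well above the methoxy compound 2.

Compound 4 is therefore expected to stay with the halogen pair, with a step of a number 2.3 percentage points lower from compound 3 to compound 4 (within the scatter) that is not expected to exceed the scatter. The estimate for compound 4 in this assay is 60%, with a range from 44% to 74%.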

Compound 4, a percentage reported as inhibition, at one concentration (the size of the read-out at that concentration, not a potency): 51.2%
Compound 4: the middle estimate sits 8.8 percentage points above what was measured; low and high end bracket the measured number.
By their numbers in this assay, from the lowest: compound 2; then compounds 4, 1 and 3 (each within the scatter of the next, the first and the last beyond it).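

In this assay, among the compounds shown here, this is the first pair with two halogens on the same aromatic carbon, and the position does not treat them alike: 3-chlorophenyl in place of 3-fluorophenyl gives a number 11.1 percentage points lower from compound 3 to compound 4 (beyond the scatter) and so separates two groups that the earlier compounds could not compare directly. The chloro compound also stays clear of the methoxy compound, with a number 11 percentage points higher from compound 2 to compound 4 (beyond the scatter) as the step, while 3-chlorophenyl in place of 4-chlorophenyl gives a number 4.6 percentage points lower from compound 1 to compound 4 (within the scatter) and leaves those two compounds unordered. The compounds therefore show a dependence on the identity of the substituent at this position, but no readable dependence on where the chloro sits, and no measurement at hand bears on the origin of the fluoro to chloro difference.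

Still open, as far as these compounds go, is where bromo, methyl or trifluoromethyl would fall on the same aromatic carbon, and whether 4-fluorophenyl would stay with 4-chlorophenyl or stand apart from it. Also open, from the compounds shown here alone, is whether the fluoro to chloro difference persists on a changed core, for instance with an amide in place of the chain amine, and whether it would appear in a full potency measurement rather than at one concentration.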